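The source may report more compounds than this note shows. Statements on the series, on what has been measured and on what is new or still open speak of the compounds shown alone.

In a functional assay on MCF7 cells (Homo sapiens) for antiproliferative activity, with a stated time of 5 days (a lower number here means a stronger inhibitor, a higher number a weaker inhibitor), compound 1 (`COc1ccc(-c2[nH]c3ccc(F)cc3c2C=C(C#N)C#N)cc1`) gives 310 nM and compound 2 (`COc1ccc(-c2[nH]c3ccc(C)cc3c2C=C(C#N)C#N)cc1`) gives 200 nM while compound 3 (`CCCc1ccc2[nH]c(-c3ccc(OC)cc3)c(C=C(C#N)C#N)c2c1`) gives 190 nM so compound 3 stands within the scatter of both others. Compound 4 (`COc1ccc(-c2[nH]c3ccc(C(C)C)cc3c2C=C(C#N)C#N)cc1`) has isopropyl in place of propyl on an aromatic carbon. Among the compounds with values here, three measured steps bear on this change (a 1.6-fold lower number from compound 1 to compound 2 (0.19 log units; within the scatter) and a 1.6-fold lower number from compound 1 to compound 3 (0.21 log units; within the scatter) and a 1.1-fold lower number from compound 2 to compound 3 (0.02 log units; within the scatter)) and each lies within the scatter. Within the data shown here, no measured pair compares isopropyl with propyl directly. No change beyond the scatter is therefore expected in this assay and the estimated step is small (a 1.1-fold higher number from compound 3 to compound 4 (0.02 log units; within the scatter)). Compound 4 is estimated at 200 nM (expected range 100 nM to 400 nM).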

Compound 4, half-maximal inhibitory concentration: 310 nM
Beside the measured number, compound 4's estimate is 1.6-fold (0.19 log units) below it, within the range that was stated.
By their numbers in this assay, from the lowest: compounds 3, 2, 1 and 4 (each within the scatter of the next).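

In this assay, isopropyl in place of propyl on an aromatic carbon gives a 1.6-fold higher number from compound 3 to compound 4 (0.21 log units; within the scatter), so the two chains cannot be told apart at this position. Isopropyl in place of methyl gives a 1.6-fold higher number from compound 2 to compound 4 (0.19 log units; within the scatter) and isopropyl in place of fluoro gives no change at the digits printed from compound 1 to compound 4 (within the scatter) in the same assay, so all four groups at this position now lie within the scatter of one another. No evidence is available to explain this flat result. On these data alone, whether an amine, a carboxylic acid or a longer chain at this position would stay within that scatter remains open.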